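Carbon-only aromatic ring in place of a cyanopyridyl

The source may hold more compounds than are shown below. What is called first, only, known or untested is meant among the compounds shown, and "the series" means these compounds.

The measured compounds:
compound 1 `COc1cc(-c2c(C)nn(-c3nc(-c4ccc(Cl)c(Cl)c4)c(SC(C)C)s3)c2C(=O)O)cc(C(F)(F)F)c1`, in a functional assay on BJAB cells (Homo sapiens) for antiproliferative activity, with a stated time of 4 days (a lower number here means that less compound is needed, a higher number that more compound is needed for the effect), compound 1 gives 1380 nM
compound 2 `Cc1nn(-c2nc(-c3ccc(Cl)c(Cl)c3)c(SC(C)C)s2)c(C(=O)O)c1-c1cncnc1`, compound 2 gives 22000 nM
compound 3 `Cc1nn(-c2nc(-c3ccc(Cl)c(Cl)c3)c(SC(C)C)s2)c(C(=O)O)c1-c1cncc(C#N)c1`, compound 3 gives 20000 nM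

Compound 3 stands second highest of the three numbers; the step of a 1.1-fold lower number from compound 2 to compound 3 (0.04 log units; within the scatter) lies within the scatter, while compound 1 sits far lower, as a 14-fold higher number from compound 1 to compound 3 (1.16 log units; beyond the scatter) shows. Compound 4 `Cc1nn(-c2nc(-c3ccc(Cl)c(Cl)c3)c(SC(C)C)s2)c(C(=O)O)c1-c1cccc(Cl)c1C` differs from compound 3 in one place: 3-chloro-2-methylphenyl in place of 5-cyanopyridin-3-yl on an aromatic carbon. Among the measured compounds shown here, the steps that bear on this are a 16-fold higher number from compound 1 to compound 2 (1.20 log units; beyond the scatter) and a 14-fold higher number from compound 1 to compound 3 (1.16 log units; beyond the scatter), both from the carbon-only ring of compound 1 to a ring holding nitrogen. Returning to a carbon-only ring, though with other substituents, is therefore expected to give a lower number in this assay, estimated as a 9.1-fold lower number from compound 3 to compound 4 (0.96 log units; beyond the scatter). Compound 4 is estimated at 2200 nM, between 700 nM and 7000 nM.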

Compound 4, half-maximal effective concentration: 5100 nM
For compound 4 the middle estimate is 2.3-fold (0.37 log units) below the measured one; the range from low to high includes it.
By their numbers in this assay, from the lowest: compound 1; then compound 4; then compounds 3 and 2 (each within the scatter of the next).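

In this assay, the 3-chloro-2-methylphenyl ring of compound 4 gives a lower number than either nitrogen-bearing ring, with a 3.9-fold lower number from compound 3 to compound 4 (0.59 log units; beyond the scatter) and a 4.3-fold lower number from compound 2 to compound 4 (0.63 log units; beyond the scatter) at this position. A carbon-only ring alone does not restore the number of compound 1, however, as a 3.7-fold higher number from compound 1 to compound 4 (0.57 log units; beyond the scatter) shows, so the substituents on such a ring also matter here. The compounds shown leave open how much of each step belongs to the ring atoms and how much to the substituents, and where a phenyl ring bearing an amine would fall. No measurement offered here explains these steps.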